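The compounds below may be only part of what the source reports. "The series", "measured", "known", "first", "only" and "open" are said of these compounds alone.

Two compounds of the series have so far been run in a functional assay on MCF7 cells (Homo sapiens) for cytotoxicity, read by MTT assay, with a stated time of 48 h; on this read-out higher numbers stand for weaker inhibition and lower numbers for stronger inhibition. Compound 1 `C=C(C)C(O)Cc1c(O)cc(CCc2ccccc2)c(C(=O)OC)c1O` gives 37900 nM in this assay, a numbered value at the weak end. Compound 2 `CC1=CCc2c(O)cc(CCc3ccccc3)cc2OC1` reaches only a limit of the assay, > 40000 nM, and no numbered value for it is in hand. Compound 2 thus stands at the limit of > 40000 nM in this assay, at which 1 of the 2 values shown sits, the upper bound of what the assay reports.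

Compound 3 `CC1=CCc2c(O)cc(CCc3ccccc3O)cc2OC1` is the next compound to be run; it differs from compound 2 by hydroxy in place of hydrogen on an aromatic carbon. No step between measured compounds is available, so nothing shown ties a change of this kind to a shift in this assay. The expected step of a number no higher from compound 2 to compound 3 (the limit leaves the size open) is therefore set at none beyond the scatter, with the outcome likely to sit once more at a limit. Compound 3 is accordingly expected near 40000 nM, within 15000 nM to 90000 nM, in this assay.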

Compound 3, half-maximal inhibitory concentration: > 40000 nM
Compound 3: no number, only a limit; the forecaster's own chance of this, stated with the estimate: 60%; the middle value sits exactly at the limit.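

No step can be read from compound 2 to compound 3, as both stop at a limit and not at a number: the limit of > 40000 nM in this assay, at which 2 of the 3 values shown sit.

The compounds shown leave open whether hydroxy in place of hydrogen on an aromatic carbon shifts the value at all in this assay.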